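The source may report more compounds than this note shows. Statements on the series, on what has been measured and on what is new or still open speak of the compounds shown alone.

Measured compounds in an assay on isolated protein for agonist activity at Bile acid receptor (Homo sapiens), read by AlphaScreen, with a stated time of 30 min; a higher number here means that more compound is needed for the effect, a lower number that less compound is needed:
- compound 2 `Cc1ccccc1-n1nc(C)c2c1NC(=O)[C@H](C)S[C@@H]2c1ccc(-c2ccsc2)cc1`: 1400 nM
- compound 3 `Cc1ccccc1-n1nc(C)c2c1NC(=O)[C@H](C)S[C@@H]2c1ccc(-c2ccco2)cc1`: 3600 nM
- compound 1 `Cc1ccccc1-n1nc(C)c2c1NC(=O)[C@H](C)S[C@@H]2c1ccc(-c2cccc(C(=O)O)c2)cc1`: "not active" (no number reported) (no number reported)

For the measured compounds named here, compound 3 holds the highest of the two numbers available; the nearest is compound 2, and the only single step, a 2.6-fold higher number from compound 2 to compound 3 (0.41 log units; beyond the scatter), is modest but beyond the scatter. Compound 1 gave no number at all in this assay.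

Compound 4 `Cc1ccccc1-n1nc(C)c2c1NC(=O)[C@H](C)S[C@@H]2c1ccc(-c2ccc(C(=O)O)cc2)cc1` differs from compound 3 as follows: 4-carboxyphenyl in place of furan-2-yl on an aromatic carbon. Going by the values given here, no measured pair reproduces this change. The step from compound 2 to compound 3 concerns two five-membered rings and says little about a carboxyphenyl group. Among the compounds with values here, the only compound carrying a carboxylic acid on the outer ring, compound 1, gave no number, which points towards a substantial rise for compound 4 and a real chance that this assay again reports no number. The expected step is therefore a 4.2-fold higher number from compound 3 to compound 4 (0.62 log units; beyond the scatter), upward. For compound 4 the estimate is 15000 nM, with a range from 5000 nM to 60000 nM.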

Compound 4, half-maximal effective concentration: "not active" (no number reported)
Nothing numeric was reported for compound 4; no gap can be computed for the estimate.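

In this assay, for the compounds shown here, compound 4 gives "not active" (no number reported) and so yields no new step against compound 3. No evidence shown bears on this result. The compounds shown leave open whether the missing numbers for compound 1 and compound 4 go with the carboxylic acid or with the six-membered outer ring.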